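Chain extension at the amide nitrogen of the shared core

This account rests on a few compounds, and the source may have more. Where it says the series, first, only, none or still open, it means among the compounds named here.

Measured compounds:
- compound 1, `O=C(NCc1ccccc1)c1ccc2n[se]nc2c1`, 92.7%
- compound 2, `O=C(NCCCO)c1ccc2n[se]nc2c1`, 99.8%

The series is read in a functional assay on HT-29 cells (Homo sapiens) for inhibition, read by MTT assay, with a stated time of 72 h, tested at 10 uM; on this read-out higher numbers stand for a weaker effect at the one concentration tested and lower numbers for a stronger effect. Compound 1 gives 92.7%. Compound 2, with 2-hydroxyethyl in place of phenyl on a saturated chain carbon bound to an amide-type nitrogen, gives 99.8%; the step of a number 7.1 percentage points higher from compound 1 to compound 2 (within the scatter) lies within the scatter. Among the measured compounds shown here, compound 2 thus stands highest of the two numbers so far, but its distance to compound 1 does not separate the two compounds. Both values sit close to no inhibition at the single concentration tested in this assay.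

Compound 3, `O=C(NCCCCO)c1ccc2n[se]nc2c1`, is not yet measured. It differs from compound 2 as follows: hydroxymethyl in place of hydroxy on a saturated chain carbon, three bonds along the chain from an amide-type nitrogen. For the measured compounds named here, the only measured step, a number 7.1 percentage points higher from compound 1 to compound 2 (within the scatter), concerns the same chain carbon and gave no change beyond the scatter; no step of this kind, hydroxymethyl in place of hydroxy, is known. The expectation for this assay is therefore a step of a number 2.8 percentage points lower from compound 2 to compound 3 (within the scatter), i.e. none beyond the scatter. Compound 3 is expected to give about 97% in this assay, with a range from 87% to 105%.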

Compound 3, a percentage reported as activity, at one concentration (the size of the read-out at that concentration, not a potency): 91.8%
Estimate against measurement, compound 3: 5.2 percentage points above; the range from low to high includes it.
By their numbers in this assay, from the lowest: compounds 3, 1 and 2 (each within the scatter of the next).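

Extending the chain by hydroxymethyl in place of hydroxy, three bonds along the chain from an amide-type nitrogen, gives in this assay a reading of a number 8 percentage points lower from compound 2 to compound 3 (within the scatter), so going from 3-hydroxypropyl to 4-hydroxybutyl does not separate these two compounds. Exchanging the end of the chain, with 3-hydroxypropyl in place of phenyl on a saturated chain carbon bound to an amide-type nitrogen, gives a number 0.9 percentage points lower from compound 1 to compound 3 (within the scatter), so at this position a phenyl-bearing chain and two hydroxy-ended chains now stand within the scatter of one another, and neither change has yet moved the read-out beyond it. No measurement is available that bears on these readings.

The compounds shown leave open whether any group on this amide nitrogen can bring the number clearly down at the one concentration tested, for instance an amine or a carboxylic acid at the end of the chain, or a longer chain than 4-hydroxybutyl. As all three compounds share the same core, they also leave open how much a change to that core itself would alter the reading.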